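The source may hold more compounds than are shown below. What is called first, only, known or untested is meant among the compounds shown, and "the series" means these compounds.

Notes on the series. Compound 1 `O=C(NCc1cc(C(F)(F)F)nn1-c1ccc(Cl)cc1)Nc1cccc2[nH]ncc12` carries a hydrogen on the aromatic nitrogen of its core; in an assay on CHO-K1 cells for antagonist activity at transient receptor potential cation channel subfamily V member 1 (Homo sapiens), read by FLIPR and calcium flux, with a stated time of 6 min (a higher number here means a weaker inhibitor, a lower number a stronger inhibitor), compound 1 gives 2.5 nM. Compound 2 `Cn1ncc2c(NC(=O)NCc3cc(C(F)(F)F)nn3-c3cccc(F)c3)cccc21` has the methylated core and a 3-fluorophenyl on the other aromatic nitrogen; in this assay compound 2 gives 7 nM. Compound 3 `Cn1ncc2c(NC(=O)NCc3cc(C(F)(F)F)nn3-c3ccc(Cl)cc3)cccc21` combines the methylated core with a 4-chlorophenyl; in this assay compound 3 gives 2.7 nM. On these numbers compound 3 stands second highest of the three, with compound 1 nearest and compound 2 furthest. Methyl in place of hydrogen on an aromatic nitrogen reads a 1.1-fold higher number from compound 1 to compound 3 (0.03 log units; within the scatter). The aryl group carries more weight: 4-chlorophenyl in place of 3-fluorophenyl on an aromatic nitrogen reads a 2.6-fold lower number from compound 2 to compound 3 (0.41 log units; beyond the scatter).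

Compound 4 `Cn1ncc2c(NC(=O)NCc3cc(C(F)(F)F)nn3-c3ccc(C(C)(C)C)cc3)cccc21` differs from compound 3 by tert-butyl in place of chloro on an aromatic carbon. Among the compounds with values here, no measured step exchanges one group for another on this aromatic carbon; the only measured change at the aryl group, a 2.6-fold lower number from compound 2 to compound 3 (0.41 log units; beyond the scatter), was of modest size. The step from compound 3 to compound 4 in this assay is therefore expected to be modest at most, direction uncertain, with a 1.9-fold higher number from compound 3 to compound 4 (0.27 log units; within the scatter) as the working estimate. Compound 4 is estimated at 5 nM in this assay, within 1.5 nM to 18 nM.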

Compound 4, inhibition constant: 13.2 nM
Estimate against measurement, compound 4: 2.6-fold (0.42 log units) below; the range from low to high includes it.
By their numbers in this assay, from the lowest: compounds 1 and 3 (each within the scatter of the next); then compounds 2 and 4 (each within the scatter of the next).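

The aromatic carbon that carries chloro in compound 3 responds to substitution in this assay: tert-butyl in place of chloro gives a step beyond the scatter (a 4.9-fold higher number from compound 3 to compound 4 (0.69 log units; beyond the scatter)), so these two groups, with 1 and 4 heavy atoms, are not interchangeable here. Having a group at this place is therefore not enough to secure the number of compound 3, since the 4-(tert-butyl)phenyl of compound 4 and the 3-fluorophenyl of compound 2 remain within the scatter of each other (a 1.9-fold higher number from compound 2 to compound 4 (0.28 log units; within the scatter)). No measurement to hand accounts for the step at this position.

A single exchange at this aromatic carbon cannot show whether the number follows the size of the group or something specific to chloro, and a methyl, a methoxy or a bromo here would help separate those readings. On these data alone, it also remains open whether tert-butyl reads the same way on the core of compound 1, which has hydrogen on its aromatic nitrogen in place of methyl.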